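Changing the group on sulfur in compound 1

This account rests on a few compounds, and the source may have more. Where it says the series, first, only, none or still open, it means among the compounds named here.

Compound 1 `Nc1ccccc1NC(=O)/C=C/c1ccc(CSc2ccc(C(F)(F)F)cn2)cc1`: 10.3%
Compound 2 `Nc1ccccc1NC(=O)c1ccc(CSc2ccc(C(F)(F)F)cn2)cc1`: 4.3%

Within the data shown here, in a functional assay on A-375 cells (Homo sapiens) for inhibition, read by CCK-8 assay, with a stated time of 72 h, tested at 2 uM (a higher number here means more inhibition of growth at the concentration tested, a lower number less inhibition of growth), compound 1 gives 10.3% and compound 2 gives 4.3%, two values within the scatter of each other, so compound 1 stands level with the only other compound measured. Compound 3 `CC(C)(C)c1ccc(SCc2ccc(/C=C/C(=O)Nc3ccccc3N)cc2)cc1` carries 4-(tert-butyl)phenyl in place of 5-(trifluoromethyl)pyridin-2-yl on a sulfur. Among the measured compounds shown here, no measured pair shows what a change at this place does, so the expectation rests on the value of compound 1, 10.3%. In this assay no change beyond the scatter is expected, with an estimated a number 2.7 percentage points higher from compound 1 to compound 3 (within the scatter). The expected value for compound 3 is 13%, within an estimated range from 2% to 32%.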

Compound 3, percent growth inhibition at one concentration: 38.4%
The estimate for compound 3 lay 25.4 percentage points below the measured number, and the stated range ends below it.
By their numbers in this assay, from the lowest: compounds 2 and 1 (each within the scatter of the next); then compound 3.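

In this assay the group on sulfur proves to matter: 4-(tert-butyl)phenyl in place of 5-(trifluoromethyl)pyridin-2-yl gives a number 28.1 percentage points higher from compound 1 to compound 3 (beyond the scatter) and so opens the first gap beyond the scatter among these compounds. This one position can therefore move the growth inhibition clearly, which the level pair of compound 1 and compound 2 could not show. Nothing measured here explains the step.

Going by these compounds, the change replaces the ring and its substituent together, so which of them carries the step stays open. On these data alone, how a plain phenyl or a morpholine ring on the sulfur would read also remains open.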